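Swapping the hydrazone aryl group: will phenyl restore potency?

The source may report more compounds than this note shows. Statements on the series, on what has been measured and on what is new or still open speak of the compounds shown alone.

Measured so far:
- compound 1, `CN(C)CCn1cnnc1-c1cc(Oc2ccc(NC(=O)N/N=C/c3c[nH]c4ccccc34)cc2F)ccn1`: 820 nM
- compound 2, `Cn1ncnc1-c1cc(Oc2ccc(NC(=O)N/N=C/c3ccccc3)cc2F)ccn1`: > 100000 nM
- compound 3, `COc1cc(/C=N/NC(=O)Nc2ccc(Oc3ccnc(-c4nncn4CCN(C)C)c3)c(F)c2)ccc1O`: > 100000 nM

In a functional assay on A549 cells (Homo sapiens) for cytotoxicity, read by MTT assay, with a stated time of 72 h (a lower number here means a stronger inhibitor, a higher number a weaker inhibitor), compound 1 gives 820 nM. For compound 3 the assay reports only a limit, > 100000 nM. For compound 2 the assay likewise reports only a limit, > 100000 nM. For the measured compounds named here, compound 3 thus stands at the weak end of what has been measured, with no number of its own, and the one step that reaches it is large: an at least 120-fold higher number from compound 1 to compound 3 (2.08 log units; beyond the scatter). This is consistent with the limit of > 100000 nM in this assay, at which 2 of the 3 values shown sit, which marks the edge of the assay rather than a measured strength.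

The next compound, compound 4, is `CN(C)CCn1cnnc1-c1cc(Oc2ccc(NC(=O)N/N=C/c3ccccc3)cc2F)ccn1`. It differs from compound 3 in one place: phenyl in place of 4-hydroxy-3-methoxyphenyl on a carbon with a double bond to nitrogen. Going by the values given here, no measured step covers exactly this change. What the data do show is that compound 2, which carries the same phenyl on the same carbon, also sits at the limit. Given that both compound 2 and compound 3 fail to register a number, the expectation is that compound 4 will behave like them and that a number no higher from compound 3 to compound 4 (the limit leaves the size open) will not move beyond the scatter. Compound 4 is therefore estimated at 100000 nM, within 20000 nM to 300000 nM, and most probably reported as a limit again.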

Compound 4, half-maximal inhibitory concentration: 1860 nM
The estimate for compound 4 lay 54-fold (1.73 log units) above the measured number, outside the stated range (below it).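

In this assay, the group on a carbon with a double bond to nitrogen turns out to decide activity even without an indole: with phenyl in place of 4-hydroxy-3-methoxyphenyl, the result is an at least 53-fold lower number from compound 3 to compound 4 (1.73 log units; beyond the scatter). Phenyl alone does not guarantee a weak compound, since holding it fixed and setting 4-(2-(dimethylamino)ethyl)-4H-1,2,4-triazol-3-yl in place of 1-methyl-1H-1,2,4-triazol-5-yl on an aromatic carbon gives an at least 53-fold lower number from compound 2 to compound 4 (1.73 log units; beyond the scatter), so the outcome with phenyl depends on the triazole group elsewhere in the molecule. Against the indole, phenyl gives up only a modest amount, a 2.3-fold higher number from compound 1 to compound 4 (0.36 log units; beyond the scatter), so most of the activity of 1H-indol-3-yl is kept by a plain phenyl, and it is 4-hydroxy-3-methoxyphenyl that stands apart among these three groups.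

On these data alone, the true size of the two large steps stays open, since compound 2 and compound 3 each stand at a limit and not at a number: the limit of > 100000 nM in this assay, at which 2 of the 4 values shown sit. Also open, as far as these compounds go, is whether the hydroxy or the methoxy of 4-hydroxy-3-methoxyphenyl carries the loss, and how a phenyl bearing a single amine or a carboxylic acid would read.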